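This account rests on a few compounds, and the source may have more. Where it says the series, first, only, none or still open, it means among the compounds named here.

Measured compounds and their numbers in a functional assay on K562 cells (Homo sapiens) for inhibition, read by thymidine incorporation, with a stated time of 48 h, tested at 10 ug/mL; on this read-out higher numbers stand for more inhibition at the one concentration tested (going by the name of the read-out) and lower numbers for less inhibition:

compound 1, `C(=C/c1ncnc2c1ncn2C1CCOCC1)\c1ccccc1`, giving 66%
compound 2, `C(=C/c1ncnc2c1ncn2C1CCOCC1)\c1cccs1`, giving 65%
compound 3, `C(=C/c1ncnc2c1ncn2C1CCOCC1)\c1ccsc1`, giving 58%

Compound 3 returns the smallest of the three numbers, yet a number 8 percentage points lower from compound 1 to compound 3 (within the scatter) and a number 7 percentage points lower from compound 2 to compound 3 (within the scatter) both fall within the usual scatter, as does a number 1 percentage points lower from compound 1 to compound 2 (within the scatter), so the three compounds cannot be told apart on this read-out.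

Compound 4, `C/C(=C\C=C\c1ncnc2c1ncn2C1CCOCC1)CO`, arises from compound 3 through one change: 2-(hydroxymethyl)prop-1-en-1-yl in place of thiophen-3-yl on a double-bonded chain carbon bound to a double-bonded chain carbon. Every measured step exchanges one aromatic ring for another aromatic ring at the same place, and all three of them are flat. None of them puts an open chain carrying a hydroxymethyl at that place, so they bear on the new step only in a loose way: they show that the aromatic ring itself can be varied without a shift beyond the scatter, but say nothing about removing the ring entirely. The expectation for compound 4 therefore rests on thin ground, and a step of a number 13 percentage points lower from compound 3 to compound 4 (beyond the scatter) is estimated, with a wide range to reflect the missing precedent. Compound 4 is expected to give 45%, estimated to lie between 15% and 70%.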

Compound 4, a percentage reported as inhibition, at one concentration (the size of the read-out at that concentration, not a potency): 27%
Compound 4: middle estimate off by 18 percentage points, on the high side; measured number inside the range.
By their numbers in this assay, from the lowest: compound 4; then compounds 3, 2 and 1 (each within the scatter of the next).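

In this assay, the place on a double-bonded chain carbon bound to a double-bonded chain carbon now proves sensitive to the group it carries: 2-(hydroxymethyl)prop-1-en-1-yl in place of an aromatic ring gives a number 31 percentage points lower from compound 3 to compound 4 (beyond the scatter), a number 38 percentage points lower from compound 2 to compound 4 (beyond the scatter) and a number 39 percentage points lower from compound 1 to compound 4 (beyond the scatter). The earlier compounds shown here showed only that phenyl, thiophen-2-yl and thiophen-3-yl could not be told apart here, whereas this open chain separates clearly from all three, even though it has as many heavy atoms as the thiophen-3-yl it replaces, so that count alone does not keep the number up. The change removes the ring and brings in a hydrogen-bond donor at once, and nothing available explains the drop or bears on its cause.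

The compounds shown leave open whether the loss follows the missing ring or the hydroxymethyl, a question that a plain 2-methylprop-1-en-1-yl chain or a saturated cyclohexyl ring at this place would help to separate. They also leave open how an amine or a carboxylic acid at the end of the chain, or a longer chain, would read out in this assay.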